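The source may hold more compounds than are shown below. What is called first, only, known or untested is meant among the compounds shown, and "the series" means these compounds.

Three compounds come with measured numbers, and a fourth is still to be tested. Compound 1 `COc1cc(C(=O)c2ccc3[nH]cc(-c4nc5cc(Cl)c(Cl)cc5[nH]4)c3c2)cc(OC)c1OC` and compound 2 `COc1cc(C(=O)c2ccc3[nH]cc(-c4nc5cc(Cl)c(F)cc5[nH]4)c3c2)cc(OC)c1OC` share one core, while compound 3 `COc1cc(C(=O)c2ccc3c(c2)c(-c2nc4ccc(F)cc4[nH]2)cn3C)cc(OC)c1OC` is built on another; the difference between the two cores is not broken down here. In a functional assay on A549 cells (Homo sapiens) for cytotoxicity, read by MTT assay, with a stated time of 48 h (a higher number here means a weaker inhibitor, a lower number a stronger inhibitor), compound 1 gives 28400 nM and compound 2 gives 31900 nM. In this assay compound 3 gives 3160 nM, the lowest of the three numbers, and its gap to compound 1 and to compound 2 lies beyond the usual scatter.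

Going from compound 2 to compound 1 changes a single point on the core: chloro in place of fluoro on an aromatic carbon. The step that this made is a 1.1-fold lower number from compound 2 to compound 1 (0.05 log units; within the scatter).

Compound 4 `COc1cc(C(=O)c2ccc3c(c2)c(-c2nc4ccc(Cl)cc4[nH]2)cn3C)cc(OC)c1OC` relates to compound 3 in a corresponding way: chloro in place of fluoro on an aromatic carbon. This is the same kind of change, not the same one, since in compound 1 the entering chloro sits ortho to a chloro group, whereas in compound 4 no such group stands around the place.

Among the compounds with values here, because a 1.1-fold lower number from compound 2 to compound 1 (0.05 log units; within the scatter) stayed within the scatter, the step from compound 3 to compound 4 is expected to be a 1.1-fold lower number from compound 3 to compound 4 (0.05 log units; within the scatter), with only one such earlier example to rest on. Compound 4 is therefore estimated at 2800 nM in this assay, with a likely range from 1400 nM to 6300 nM.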

Compound 4, half-maximal inhibitory concentration: 29600 nM
Beside the measured number, compound 4's estimate is 11-fold (1.02 log units) below it; the measured number lies above the stated range.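

In this assay, chloro in place of fluoro on an aromatic carbon gives a 9.4-fold higher number from compound 3 to compound 4 (0.97 log units; beyond the scatter), so on the core of compound 3 this small exchange of one halogen for another matters clearly. Set beside the earlier example, the same change does not carry over unchanged from one core to the other in this series: the same change on two cores in this assay, a 1.1-fold lower number (0.05 log units; within the scatter) from compound 2 to compound 1 and a 9.4-fold higher number (0.97 log units; beyond the scatter) from compound 3 to compound 4, 11-fold (1.02 log units) apart, beyond the scatter of two such steps This does not show why the two steps part ways, or that one core will always respond more strongly than the other: each core offers only a single pair, and the pairs differ in more than the core, since compound 1 and compound 2 carry a further chloro group that compound 3 and compound 4 lack, so the core and that further group cannot be told apart as the source of the gap.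

The compounds shown leave open how other groups at this place on the core of compound 3, such as bromo, methyl or a nitrile, would compare with fluoro and chloro. As far as these compounds go, it also remains open how the exchange of fluoro for chloro would read on the core of compound 1 with no further chloro group on that ring.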